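The source may report more compounds than this note shows. Statements on the series, on what has been measured and on what is new or still open speak of the compounds shown alone.

Working notes on the series. Compound 1 `C=C1C[C@]23C[C@@]1(O)CC[C@H]2c1ccc(OS(=O)(=O)c2ccc(C)cc2)c(C)c1[C@@H]3Cn1cc(-c2ccc(Br)cc2)nn1` carries a 4-bromophenyl group; in a functional assay on SW480 cells (Homo sapiens) for cytotoxicity, read by MTT assay, with a stated time of 4 days (on this read-out higher numbers stand for weaker inhibition and lower numbers for stronger inhibition), compound 1 reaches only the assay limit of > 20000 nM. Compound 2 `C=C1C[C@]23C[C@@]1(O)CC[C@H]2c1ccc(OS(=O)(=O)c2ccc(C)cc2)c(C)c1[C@@H]3Cn1cc(-c2ccc(OC)cc2)nn1` carries a 4-methoxyphenyl group in its place; in this assay compound 2 likewise stops at the limit, > 20000 nM. The change bromo in place of methoxy on an aromatic carbon therefore gives a step that the two limits leave unreadable from compound 2 to compound 1 that the two limits leave unreadable. Compound 3 `COc1ccc(-c2cn(C[C@H]3c4c(ccc(OS(=O)(=O)c5ccc(C)cc5)c4C)[C@@H]4CC[C@@]5(C)C[C@]43CC5=O)nn2)cc1` keeps the 4-methoxyphenyl group on another core; the difference between the cores of compound 2 and compound 3 is not broken down here. In this assay compound 3 also returns only a limit, > 20000 nM.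

Compound 4 `Cc1ccc(S(=O)(=O)Oc2ccc3c(c2C)[C@H](Cn2cc(-c4ccc(Br)cc4)nn2)[C@@]24CC(=O)[C@@](C)(CC[C@@H]32)C4)cc1` is still to be measured in this assay. It differs from compound 3 by bromo in place of methoxy on an aromatic carbon, the same change as that from compound 2 to compound 1, at a place described in identical words. The step from compound 3 to compound 4 is expected to be a step that the limit leaves unreadable from compound 3 to compound 4, an expectation that rests only on the limit of > 20000 nM in this assay, at which 3 of the 3 values shown sit, and on the unreadable earlier step. Compound 4 is accordingly estimated at 40000 nM, within 15000 nM to 150000 nM, most likely reported again as a limit.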

Compound 4, half-maximal inhibitory concentration: > 20000 nM
Compound 4 gave a limit, no number (the forecaster's own chance of this, stated with the estimate: 85%); the middle value is on the limit's open side.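

In this assay compound 4 returns only a limit, > 20000 nM, as compound 3 did, so no size can be read for the change from compound 3 to compound 4. The compounds shown leave open whether 4-methoxyphenyl or 4-bromophenyl makes any difference on either core, and how the two cores compare, all readings resting on one limit: the limit of > 20000 nM in this assay, at which 4 of the 4 values shown sit.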